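A few compounds are considered here, and "the series" means these few. Any claim that something is new, unique, unknown or untested is made for them only; others in the source may bear on it.

The measured compounds and their values:

Compound 1 `C=CC1=C(C(=O)NCCC)C(c2ccc(F)cc2)OC1` gives in a functional assay on A549 cells (Homo sapiens) for cytotoxicity, read by MTT assay, with a stated time of 24 h (on this read-out higher numbers stand for weaker inhibition and lower numbers for stronger inhibition), a value of > 100000 nM, which is a limit of the assay rather than a number.
Compound 2 `C=CC1=C(C(=O)NC2CCCCC2)C(c2ccc(OC)c(OC)c2)OC1` gives in this assay a value of > 100000 nM, again a limit of the assay.
Compound 3 `C=CC1=C(C(=O)NC2CCCCC2)C(c2ccc(F)cc2)OC1` gives in this assay a value of > 100000 nM, also a limit of the assay.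

All three compounds share a core with a vinyl-bearing ring and an amide; they differ in the group on the amide nitrogen and in the aromatic ring attached to the core. The difference between the cores of compound 2 and compound 3 is not broken down here. Between compound 3 and compound 1 one change is made: propyl in place of cyclohexyl on an amide-type nitrogen. The step that the two limits leave unreadable from compound 3 to compound 1 cannot be sized, because the limit of > 100000 nM in this assay, at which 3 of the 3 values shown sit, leaves the two values indistinguishable.

Compound 4 `C=CC1=C(C(=O)NCCC)C(c2ccc(OC)c(OC)c2)OC1` has not yet been measured. It arises from compound 2 by the same change: propyl in place of cyclohexyl on an amide-type nitrogen. The surroundings of the place are the same in both pairs, so this is the same change, made on a different core.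

Going by the values given here, the step from compound 2 to compound 4 is expected to be a number no higher from compound 2 to compound 4 (the limit leaves the size open), because the only measured example of this change, a step that the two limits leave unreadable from compound 3 to compound 1, stayed at the limit and all three values sit at the limit of > 100000 nM in this assay, at which 3 of the 3 values shown sit. Compound 4 is therefore estimated to give 100000 nM in this assay, most likely again reported only as a limit, with a range from 50000 nM to 300000 nM.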

Compound 4, half-maximal inhibitory concentration: > 100000 nM
Compound 4 was reported as a limit; the forecaster's own chance of this, stated with the estimate: 85%; the middle value lies on the limit itself.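

In this assay compound 4 gives > 100000 nM as a limit of the assay, not a number. The steps from compound 2 to compound 4 and from compound 3 to compound 1 therefore cannot be read, because the values cannot be told apart: the limit of > 100000 nM in this assay, at which 4 of the 4 values shown sit.

The compounds shown leave open whether putting propyl in place of cyclohexyl changes cytotoxicity at all on this shared core.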